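Compound 1 to compound 4: one side group exchanged

The source may report more compounds than this note shows. Statements on the series, on what has been measured and on what is new or still open speak of the compounds shown alone.

Compound 1 `COc1ccc(/C=C\c2cc(OC)c(OC)c(OC)c2)cc1OCc1ccc(CN2CCCC[C@@H]2C(=O)O)cc1` gives only a limit in an ADME assay on NCM460 cells (Homo sapiens) for cytotoxicity, read by CCK-8 assay, with a stated time of 48 h; on this read-out lower numbers stand for stronger inhibition and higher numbers for weaker inhibition (> 50000 nM). Compound 4 `COc1ccc(/C=C\c2cc(OC)c(OC)c(OC)c2)cc1OCc1ccc(CN2CC[C@H](O)C2)cc1` has 3-hydroxypyrrolidin-1-yl in place of 2-carboxypiperidin-1-yl on a saturated chain carbon bound to an aromatic carbon. One measured step also removes 2-carboxypiperidin-1-yl: compound 2 `COc1ccc(/C=C\c2cc(OC)c(OC)c(OC)c2)cc1OCc1ccc(CNCCO)cc1` reads 39000 nM in this assay, and an at least 1.2-fold lower number from compound 1 to compound 2 (0.10 log units; that floor lies within the scatter) is that step. Compound 3 `COc1ccc(/C=C\c2cc(OC)c(OC)c(OC)c2)cc1OCc1ccc(CN2CCCCC2C(=O)NCCNC(=O)OC(C)(C)C)cc1` gives 28000 nM on the same read-out. Among the compounds with values here, with only that small step as a guide, the expected at least 1.3-fold lower number from compound 1 to compound 4 (0.14 log units; that floor lies within the scatter) is modest, towards lower numbers, and may not clear the scatter. For compound 4 the estimated value is 36000 nM (expected range 16000 nM to 60000 nM).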

Compound 4, half-maximal inhibitory concentration: 51000 nM
Compound 4: middle estimate off by 1.4-fold (0.15 log units), on the low side; low and high end bracket the measured number.
By their numbers in this assay, from the lowest: compounds 3, 2 and 4 (each within the scatter of the next).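

Putting 3-hydroxypyrrolidin-1-yl in place of (2-hydroxyethyl)amino on a saturated chain carbon bound to an aromatic carbon gives a 1.3-fold higher number from compound 2 to compound 4 (0.12 log units; within the scatter). In this assay, the open chain and the five-membered ring therefore cannot be told apart at this place. Compound 1 gives only a limit, so its step to compound 4 cannot be read: the limit of > 50000 nM in this assay, at which 1 of the 4 values shown sits.

Still open, as far as these compounds go, is whether a group without a hydroxyl, such as dimethylamino or an unsubstituted piperidine, would read differently at this place. From the compounds shown here alone, a morpholine there is equally open.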